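The source may hold more compounds than are shown below. What is called first, only, known or untested is meant among the compounds shown, and "the series" means these compounds.

For the measured compounds named here, in an ADME assay on CHO cells (Cricetulus griseus) for cytotoxicity, read by MTT assay, with a stated time of 24 h (on this read-out lower numbers stand for higher toxicity in this test and higher numbers for lower toxicity in this test), compound 1 `CC1Cn2c(nc([N+](=O)[O-])c2Br)O1` gives 9190 nM, the only actual number in the set. Compound 2 `CCCOc1ccc(-c2c([N+](=O)[O-])nc3n2CC(C)O3)cc1` stands at > 125000 nM, which is a limit. Compound 3 `CC1Cn2c(nc([N+](=O)[O-])c2-c2ccc(OC(F)(F)F)cc2)O1` stands at > 125000 nM, which is also a limit. Going by the values given here, the one measured step, a step that the two limits leave unreadable from compound 2 to compound 3, has no readable size, and the series is left with the limit of > 125000 nM in this assay, at which 2 of the 3 values shown sit. Compound 4 `CC1Cn2c(nc([N+](=O)[O-])c2C#CC2CC2)O1` comes from compound 1 by 2-cyclopropylethynyl in place of bromo on an aromatic carbon, with 2-cyclopropylethynyl in place of bromo on an aromatic carbon. No measured step sizes this change. A shift to higher numbers in this assay is still expected, resting on compound 2 and its limit of > 125000 nM. The expected move is a 5.4-fold higher number from compound 1 to compound 4 (0.74 log units; beyond the scatter). For compound 4 the estimate is 50000 nM, with an expected range of 12000 nM to 125000 nM.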

Compound 4, half-maximal cytotoxic concentration: 6450 nM
For compound 4 the middle estimate is 7.8-fold (0.89 log units) above the measured one; the measured number lies below the stated range.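

In this assay, for the compounds shown here, replacing bromo with 2-cyclopropylethynyl on the aromatic carbon gives the first readable step at this position: a 1.4-fold lower number from compound 1 to compound 4 (0.15 log units; within the scatter). Compound 1 and compound 4 therefore cannot be told apart here, despite the added triple bond and three-membered ring. Compound 2 and compound 3 remain limits, not numbers, so this pair stays separate from them: the limit of > 125000 nM in this assay, at which 2 of the 4 values shown sit.

On these data alone, it remains open whether the triple bond or the cyclopropyl ring governs this result. An amine or a longer chain at the end of the triple bond could test this.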